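Shortening the Phosphate Alkyl Chain of a Dithiocarbamate Ester

The compounds below may be only part of what the source reports. "The series", "measured", "known", "first", "only" and "open" are said of these compounds alone.

Compound 1 `CCCCCCCCCCCCCCCCOP(=O)(O)OCCSC(=S)N1CCCCC1` carries a hexadecyl chain on the phosphate. In a functional assay on PC-3 cells (Homo sapiens) for inhibition, read by MTT assay, with stated times of 18 h and 4 h (a higher number here means a weaker inhibitor, a lower number a stronger inhibitor), compound 1 gives 34300 nM, the lowest of the two numbers recorded, with compound 3 `CCCCCCCCCCOP(=O)(O)OCCSC(=S)N1CCN(C)CC1` next at 80000 nM in this assay. Compound 2 `CCCOP(=O)(O)OCCSC(=S)N1CCCC1` reaches only the limit of this assay, > 100000 nM. That limit is the limit of > 100000 nM in this assay, at which 1 of the 3 values shown sits. Compound 4 `CCCCCCCCOP(=O)(O)OCCSC(=S)N1CCCCC1` has not yet been measured in this assay and differs from compound 1 by hydrogen in place of octyl on a saturated chain carbon, eight bonds along the chain from an oxygen on an unsaturated carbon. Within the data shown here, no step between measured compounds is available to calibrate this change. Since both compounds with shorter chains, compound 2 and compound 3, sit at the weaker end, compound 4 is expected to be weaker than compound 1, with a step of a 2.2-fold higher number from compound 1 to compound 4 (0.34 log units; beyond the scatter) expected beyond the scatter. Compound 4 is estimated at 75000 nM, between 35000 nM and 160000 nM.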

Compound 4, half-maximal inhibitory concentration: > 100000 nM
Compound 4: a limit, no number; the forecaster's own chance of this, stated with the estimate: 35%; middle value at least 1.3-fold (0.12 log units) from the limit.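

Cutting the hexadecyl chain of compound 1 back by octyl, on a saturated chain carbon, eight bonds along the chain from an oxygen on an unsaturated carbon, gives in this assay an at least 2.9-fold higher number from compound 1 to compound 4 (0.46 log units; beyond the scatter), the first reading of a change at this position alone. Compound 4 gives > 100000 nM, which is a limit and not a number. The outer part of the chain therefore matters here, and the shortened compound joins the compounds at the end of the assay's range: the limit of > 100000 nM in this assay, at which 2 of the 4 values shown sit.

Going by these compounds, the true size of the step stays open. So does whether a dodecyl chain or a chain longer than hexadecyl on the phosphate would keep or improve on compound 1.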